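This account rests on a few compounds, and the source may have more. Where it says the series, first, only, none or still open, it means among the compounds named here.

Two compounds built on a shared core, each carrying a phenethyl group and an amide-linked side chain, have been tested so far in an assay on CHO-K1 cells for displacement of a labelled ligand from adenosine receptor A1 (Homo sapiens), with a stated time of 2 h; a higher number here means a weaker inhibitor, a lower number a stronger inhibitor. Compound 1, `Cc1cc(-c2c(CCc3ccccc3)c3cc(OCC(=O)NC(C)(C)c4ccccc4)ccc3[nH]c2=O)on1`, gives 12 nM. Compound 2, `CC[C@H](NC(=O)COc1ccc2[nH]c(=O)c(-c3nccs3)c(CCc3ccccc3)c2c1)c1ccccc1`, gives 8.6 nM in this assay. Compound 2 therefore has the lowest of the two numbers, but the gap to compound 1 lies within the scatter, so the two cannot be ranked against each other.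

Compound 3, `O=C(COc1ccc2[nH]c(=O)c(-c3nccs3)c(CCc3ccccc3)c2c1)NC1(c2ccccc2)CC1`, has not yet been measured in this assay. It differs from compound 2 in one place: 1-phenylcyclopropyl in place of 1-phenylpropyl on an amide-type nitrogen. The amide nitrogen and everything beyond it in the core are unchanged, and the group that enters carries the same count of heavy atoms as the one that leaves.

Among the measured compounds shown here, with no measured step of this kind to lean on, the change is expected to bring at most a step within the scatter, and the step from compound 2 to compound 3 is estimated as a 1.2-fold higher number from compound 2 to compound 3 (0.07 log units; within the scatter). Compound 3 is accordingly expected to give about 10 nM in this assay, with a plausible range from 4 nM to 30 nM.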

Compound 3, inhibition constant: 13 nM
Compound 3: the middle estimate sits 1.3-fold (0.11 log units) below what was measured, within the range that was stated.
By their numbers in this assay, from the lowest: compounds 2, 1 and 3 (each within the scatter of the next).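

In this assay, among the compounds shown here, putting 1-phenylcyclopropyl in place of 1-phenylpropyl on the amide-type nitrogen gives a 1.5-fold higher number from compound 2 to compound 3 (0.18 log units; within the scatter), which makes this the only comparison so far in which just one place differs. The group that leaves has one defined stereocentre and an open chain, while the group that enters has no defined stereocentre and a three-membered ring, so for this pair, the two groups with the same count of heavy atoms cannot be told apart in this read-out. The data shown offer no measured explanation for why the two groups read alike.

Going by these compounds, both groups carry a phenyl ring, so it remains open whether the ring is needed on this carbon; a plain cyclopropyl group on the same nitrogen would test that directly. On these data alone, it is also open how far the tolerance for change extends, for example to a 1-phenylcyclobutyl group with its four-membered ring, or to a phenyl ring bearing a carboxylic acid or an amine.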